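A few compounds are considered here, and "the series" means these few. Any claim that something is new, unique, unknown or untested is made for them only; others in the source may bear on it.

Measured so far:
- compound 1 `CCCc1cc(N)c2cc(NC(=O)c3ccc(C(F)(F)F)cc3)ccc2n1`: 10000 nM
- compound 2 `CCCc1cc(N2CCC2)c2cc(NC(=O)/C=C/c3ccc(C(F)(F)F)cc3)ccc2n1`: 2.8 nM

Compound 1 and compound 2 differ in more than one place, so their two values are taken only as they stand. Among the compounds with values here, in an assay on isolated protein for displacement of a labelled ligand from melanin-concentrating hormone receptor 1 (Homo sapiens) (a lower number here means a stronger inhibitor, a higher number a weaker inhibitor), compound 2 gives 2.8 nM and compound 1 gives 10000 nM; compound 2 holds the lowest number of the two, with compound 1 as the only neighbour, far beyond the scatter.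

Compound 3 `CCCc1cc(OC)c2cc(NC(=O)/C=C/c3ccc(C(F)(F)F)cc3)ccc2n1` is not yet measured in this assay. It differs from compound 2 by methoxy in place of azetidin-1-yl on an aromatic carbon. Within the data shown here, no measured pair in the set isolates this change, so the size of the step is open. A move towards a higher number in this assay is expected, moderate rather than large, since the rest of compound 2 stays intact.

For compound 3 the estimate in this assay is 30 nM, range 5 nM to 300 nM, an expected step of an 11-fold higher number from compound 2 to compound 3 (1.03 log units; beyond the scatter).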

Compound 3, half-maximal inhibitory concentration: 26 nM
For compound 3 the middle estimate is 1.2-fold (0.06 log units) above the measured one; the measured number falls inside the stated range.
By their numbers in this assay, from the lowest: compound 2; then compound 3; then compound 1.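

In this assay, within the data shown here, methoxy in place of azetidin-1-yl on the aromatic carbon opposite the ring nitrogen gives a 9.3-fold higher number from compound 2 to compound 3 (0.97 log units; beyond the scatter) and is the first change that can be read in one place. This position is therefore sensitive to its substituent, though the step is modest: with the rest of the structure unchanged, compound 3 stands at 26 nM and the four-membered ring is not required for nanomolar binding here. No measurement available speaks to the cause of this step.

Open, on these data alone, is whether the step follows from losing the ring or from exchanging the attached nitrogen for oxygen, a question that a dimethylamino or an ethoxy group at this position would separate. Also open, as far as these compounds go, is how a pyrrolidin-1-yl group or a longer alkoxy chain would compare with azetidin-1-yl.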